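A Methyl-to-Methoxy Swap Repeated on a Second Core

A few compounds are considered here, and "the series" means these few. Any claim that something is new, unique, unknown or untested is made for them only; others in the source may bear on it.

Compound 2 `Cc1ccc(/C=C2\S/C(=N\c3csc(-c4ccc(Cl)cc4)c3)NC2=O)cc1` and compound 1 `COc1ccc(/C=C2\S/C(=N\c3csc(-c4ccc(Cl)cc4)c3)NC2=O)cc1` share one core and differ at a single point, with methoxy in place of methyl on an aromatic carbon. In a functional assay on SW-620 cells (Homo sapiens) for cytotoxicity, read by MTT assay, with a stated time of 72 h (a higher number here means a weaker inhibitor, a lower number a stronger inhibitor), compound 2 gives 1500 nM, while compound 1 gives 28100 nM, a change of a 19-fold higher number from compound 2 to compound 1 (1.27 log units; beyond the scatter).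

Compound 3 `Cc1ccc(/C=C2\S/C(=N\c3nc(-c4ccc(Cl)cc4)cs3)NC2=O)cc1` carries a different core; how its core differs from that of compound 2 is not broken down here. In this assay, for the measured compounds named here, compound 3 gives 890 nM, a number that sits close to the one of compound 2, too close for the two to be ranked.

Compound 4 `COc1ccc(/C=C2\S/C(=N\c3nc(-c4ccc(Cl)cc4)cs3)NC2=O)cc1` is to compound 3 what compound 1 is to compound 2: methoxy in place of methyl on an aromatic carbon, at the same place on the ring. The change is therefore the same, only made on the core of compound 3.

Because the earlier swap moved the number by a 19-fold higher number from compound 2 to compound 1 (1.27 log units; beyond the scatter), a step of roughly that size, a 13-fold higher number from compound 3 to compound 4 (1.13 log units; beyond the scatter), is expected from compound 3 to compound 4 in this assay. For compound 4 the expected value is 12000 nM, estimated to fall between 3000 nM and 40000 nM.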

Compound 4, half-maximal inhibitory concentration: 50 nM
The estimate for compound 4 lay 240-fold (2.38 log units) above the measured number; the whole stated range lies above it.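

In this assay, putting methoxy in place of methyl on the core of compound 3 gave an 18-fold lower number from compound 3 to compound 4 (1.25 log units; beyond the scatter), so here the swap strengthened the compound, whereas on the core of compound 2 it weakened it. The same small change therefore pulled in opposite directions on the two cores, and the gap between the two steps is far larger than the noise of the measurements: the same change on two cores in this assay, a 19-fold higher number (1.27 log units; beyond the scatter) from compound 2 to compound 1 and an 18-fold lower number (1.25 log units; beyond the scatter) from compound 3 to compound 4, 330-fold (2.52 log units) apart, beyond the scatter of two such steps This shows that, in this series, the result of the 4-methylphenyl to 4-methoxyphenyl change cannot simply be carried from one core to the other, although it does not show why the cores respond differently, and two cores are too few to support a general rule.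

The compounds shown leave open whether a hydroxyl or an ethoxy group at this same place would split the two cores in the same way. They also leave open whether the reversal would appear on a third core.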